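The compounds below may be only part of what the source reports. "The series", "measured", "known", "first", "only" and "open" are said of these compounds alone.

Three compounds have been measured in an assay on HEK293 cells for displacement of a labelled ligand from P2X purinoceptor 7 (Homo sapiens), read by scintillation counting, with a stated time of 1 h; a higher number here means a weaker inhibitor, a lower number a stronger inhibitor:

compound 1, `O=C(NCc1ccc(Cl)cc1Cl)[C@@H]1CCC(=O)N1c1cccs1`: 147 nM
compound 2, `O=C(NCc1ccc(Cl)cc1Cl)[C@@H]1CCC(=O)N1c1ccsc1`: 256 nM
compound 3, `O=C(NCc1ccc(Cl)cc1Cl)[C@@H]1CCC(=O)N1c1ccco1`: 118 nM

Compound 3 carries the lowest number of the three. Its gap to compound 2 is real but modest, a 2.2-fold lower number from compound 2 to compound 3 (0.34 log units; beyond the scatter), whereas its gap to compound 1, a 1.2-fold lower number from compound 1 to compound 3 (0.10 log units; within the scatter), is within the scatter, so compound 1 and compound 3 cannot be told apart on these numbers.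

Compound 4, `O=C(NCc1ccc(Cl)cc1Cl)[C@@H]1CCC(=O)N1c1ccoc1`, is the next compound, and it differs from compound 3 only in furan-3-yl in place of furan-2-yl on an amide-type nitrogen in a ring. For the measured compounds named here, the one measured step that bears on this change is the corresponding shift on the thiophene pair, a 1.7-fold higher number from compound 1 to compound 2 (0.24 log units; within the scatter), which stayed within the scatter. Going by the values given here, no other pair in the set speaks to the move from a 2-yl to a 3-yl attachment.

On that basis the step is expected to be small and, if anything, towards a higher number, a 1.5-fold higher number from compound 3 to compound 4 (0.18 log units; within the scatter), and likely within the scatter. Compound 4 is therefore estimated at 180 nM in this assay, with a range from 80 nM to 400 nM.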

Compound 4, inhibition constant: 86 nM
Beside the measured number, compound 4's estimate is 2.1-fold (0.32 log units) above it; the range from low to high includes it.
By their numbers in this assay, from the lowest: compounds 4, 3, 1 and 2 (each within the scatter of the next, the first and the last beyond it).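

In this assay the change from furan-2-yl to furan-3-yl on an amide-type nitrogen in a ring gives a step within the scatter (a 1.4-fold lower number from compound 3 to compound 4 (0.14 log units; within the scatter)), so the furan pair, like the thiophene pair (a 1.7-fold higher number from compound 1 to compound 2 (0.24 log units; within the scatter)), does not show that the point of attachment matters at this position. The new compound also sharpens the comparison between the two heteroaromatic groups: furan-3-yl in place of thiophen-3-yl gives a modest step beyond the scatter (a 3.0-fold lower number from compound 2 to compound 4 (0.47 log units; beyond the scatter)), while furan-3-yl in place of thiophen-2-yl stays within it (a 1.7-fold lower number from compound 1 to compound 4 (0.23 log units; within the scatter)), which leaves compound 2 apart from both furan compounds but not from compound 1. Nothing available here accounts for these steps.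

The compounds shown vary only among furan and thiophene groups attached at this nitrogen, so it remains open how the position would respond to a phenyl or a pyridin-3-yl group, or to a methyl group on the furan-3-yl ring. Whether the narrow spread among these groups holds for such changes cannot be told from these four compounds.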